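This account rests on a few compounds, and the source may have more. Where it says the series, first, only, none or still open, it means among the compounds named here.

Compound 1, `Cn1c(=O)c(S(=O)(=O)c2ccc(F)cc2F)cc2cnc(Nc3ccc4occc4c3)nc21`: in a functional assay on DU-145 cells (Homo sapiens) for inhibition, read by trypan blue exclusion, with a stated time of 72 h (a lower number here means a stronger inhibitor, a higher number a weaker inhibitor), compound 1 gives 15000 nM.
Compound 2, `Cn1c(=O)c(S(=O)(=O)c2ccc(F)cc2F)cc2cnc(Nc3ccncn3)nc21`: in this assay compound 2 gives 50000 nM.

Compound 2 stands highest of these two numbers; its nearest neighbour is compound 1, and the step of a 3.3-fold higher number from compound 1 to compound 2 (0.52 log units; beyond the scatter) lies beyond the scatter. Compound 3, `Cn1c(=O)c(S(=O)(=O)c2ccc(F)cc2F)cc2cnc(Nc3ccc4cccc(O)c4n3)nc21`, has not yet been measured. It differs from compound 2 in one place: 8-hydroxyquinolin-2-yl in place of pyrimidin-4-yl on a nitrogen on an aromatic ring.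

Among the measured compounds shown here, only one measured step bears on this change. From compound 1 to compound 2 a bicyclic aromatic group on that nitrogen gave way to a single six-membered ring with two hetero atoms, and the number rose by a 3.3-fold higher number from compound 1 to compound 2 (0.52 log units; beyond the scatter). The change from compound 2 to compound 3 runs the other way, restoring a bicyclic group, now one carrying a hydroxyl and a ring nitrogen. For the measured compounds named here, compound 3 is therefore expected to give a lower number than compound 2 in this assay, with a step of about a 4.2-fold lower number from compound 2 to compound 3 (0.62 log units; beyond the scatter), roughly the size of the one seen between compound 1 and compound 2. The estimate for compound 3 is 12000 nM, within a range of 3000 nM to 45000 nM.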

Compound 3, half-maximal inhibitory concentration: 5000 nM
Estimate against measurement, compound 3: 2.4-fold (0.38 log units) above, within the range that was stated.
By their numbers in this assay, from the lowest: compound 3; then compound 1; then compound 2.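

In this assay the 8-hydroxyquinolin-2-yl group on the nitrogen gives a 10-fold lower number from compound 2 to compound 3 (1.00 log units; beyond the scatter) and also outdoes the other two-ring group, with a 3.0-fold lower number from compound 1 to compound 3 (0.48 log units; beyond the scatter) on the same position. Among the compounds shown here, the earlier pair showed only that a two-ring group and a single ring could differ here, whereas this result shows that the position also separates one two-ring group from another, so having two rings does not by itself set the number, and the order now runs from 8-hydroxyquinolin-2-yl through 1-benzofuran-5-yl to pyrimidin-4-yl. Nothing given here accounts for these differences.

The change from pyrimidin-4-yl brings in the hydroxyl, the quinoline ring nitrogen and a second ring all at once, and the three compounds shown cannot tell which of these parts carries the step. On these data alone, a plain quinolin-2-yl group, or an 8-methoxyquinolin-2-yl group with a methoxy in place of the hydroxyl, would begin to separate them, and whether the order holds beyond these cells stays open as well.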